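Moving an isopropyl onto the amidine of a rearranged core

The source may report more compounds than this note shows. Statements on the series, on what has been measured and on what is new or still open speak of the compounds shown alone.

Compound 1 `N=C(N)c1ccc2oc(-c3cccc(OCCCCOc4ccccc4)c3)cc2c1` and compound 3 `N=C(N)c1ccc2cc(-c3cccc(OCCCCOc4ccccc4)c3)oc2c1` are built from the same atoms joined differently; the difference between the two cores is not broken down here. In an ADME assay on L6 cells (Rattus norvegicus) for cytotoxicity, read by resazurin assay, with a stated time of 70 h (on this read-out higher numbers stand for weaker inhibition and lower numbers for stronger inhibition), compound 1 gives 8100 nM and compound 3 gives 7600 nM, two numbers that lie within the usual scatter of each other. Compound 2 `CC(C)NC(=N)c1ccc2oc(-c3cccc(OCCCCOc4ccccc4)c3)cc2c1` carries one change against compound 1, (isopropyl in place of hydrogen on an amine nitrogen), and in this assay compound 2 gives 36500 nM, so that a 4.5-fold higher number from compound 1 to compound 2 (0.65 log units; beyond the scatter).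

Compound 4 `CC(C)NC(=N)c1ccc2cc(-c3cccc(OCCCCOc4ccccc4)c3)oc2c1` stands to compound 3 exactly as compound 2 stands to compound 1: the change is isopropyl in place of hydrogen on an amine nitrogen, at the same place in both pairs. With compound 3 starting close to compound 1, the expectation is that compound 4 follows the same path, and the step of a 4.5-fold higher number from compound 3 to compound 4 (0.65 log units; beyond the scatter) is estimated to match the earlier one because of a 4.5-fold higher number from compound 1 to compound 2 (0.65 log units; beyond the scatter). On that basis compound 4 is expected to give about 34000 nM in this assay, most likely between 15000 nM and 75000 nM; this rests on a single earlier pair and nothing more.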

Compound 4, half-maximal inhibitory concentration: 46500 nM
The estimate for compound 4 lay 1.4-fold (0.14 log units) below the measured number; low and high end bracket the measured number.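

In this assay, the isopropyl change on the second core moves the number in the same direction as on the first, with a 6.1-fold higher number from compound 3 to compound 4 (0.79 log units; beyond the scatter), meaning weaker inhibition of the L6 cells. Within this small set, the step carries over from one core to the other with no measurable loss or gain in size: the same change on two cores in this assay, a 4.5-fold higher number (0.65 log units; beyond the scatter) from compound 1 to compound 2 and a 6.1-fold higher number (0.79 log units; beyond the scatter) from compound 3 to compound 4, 1.4-fold (0.13 log units) apart, within the scatter of two such steps

This agreement rests on just two pairs, so it shows that the change behaved alike on these two cores and cannot establish a rule for other cores, for other groups on the amine nitrogen or for other assays. It also gives no reason why isopropyl raises the number.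

The compounds shown leave open whether a smaller group such as methyl on the same nitrogen would give a smaller step, or whether a cyclohexyl would give a larger one. Going by these compounds alone, they also leave open whether the step would hold up if a shorter chain replaced the one carrying the phenoxy group.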